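From compound 3 to compound 4: a step without numbers

The compounds below may be only part of what the source reports. "The series", "measured", "known", "first", "only" and "open" are said of these compounds alone.

Measured so far in a functional assay on HepG2 cells (Homo sapiens) for antiproliferative activity, read by MTT assay, with a stated time of 24 h; a lower number here means a stronger inhibitor, a higher number a weaker inhibitor:
- compound 1 `COc1cccc(/C=C/C(=O)c2ccc(OC)c3c2OC(C)(C)C=C3)c1` gives > 10000 nM
- compound 2 `COc1ccc(C(=O)/C=C/c2cc(OC)c(OC)c(OC)c2)c2c1C=CC(C)(C)O2` gives > 10000 nM
- compound 3 `COc1ccc(C(=O)/C=C/c2cccc(F)c2)c2c1C=CC(C)(C)O2` gives > 10000 nM

Each entry is a limit of the assay and not a number.

Compound 3 stands at > 10000 nM as a limit. Within the data shown here, the series so far offers only the limit of > 10000 nM in this assay, at which 3 of the 3 values shown sit, and no number to work from.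

Compound 4 `COc1ccc(C(=O)/C=C/c2ccc(N(C)C)cc2)c2c1C=CC(C)(C)O2` carries 4-(dimethylamino)phenyl in place of 3-fluorophenyl on a double-bonded chain carbon bound to a double-bonded chain carbon. Among the measured compounds shown here, the one measured step that bears on it is a step that the two limits leave unreadable from compound 1 to compound 3 and it gives no size to carry over. No size or direction can be taken from the data, so no step beyond the scatter is expected in this assay on this evidence. The estimated step is a number no higher from compound 3 to compound 4 (the limit leaves the size open) and it is expected to stay within the scatter. Another limit reading is the likeliest result. For compound 4 the estimate is 10000 nM with an expected range from 3000 nM to 30000 nM in the same read-out.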

Compound 4, half-maximal inhibitory concentration: 730 nM
Beside the measured number, compound 4's estimate is 14-fold (1.14 log units) above it, and the stated range ends above it.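

In this assay, the group on the double-bonded chain carbon bound to a double-bonded chain carbon now proves able to move the read-out: 4-(dimethylamino)phenyl in place of 3-fluorophenyl brings an at least 13-fold lower number from compound 3 to compound 4 (1.13 log units; beyond the scatter), and in place of 3-methoxyphenyl it brings an at least 13-fold lower number from compound 1 to compound 4 (1.13 log units; beyond the scatter). Both steps lie beyond the scatter, whereas the earlier step at this position, between compound 1 and compound 3, cannot be read. Compound 4 gives the only actual number in the series so far, and the other compounds remain at an assay limit: the limit of > 10000 nM in this assay, at which 3 of the 4 values shown sit.

The compounds shown leave open whether the step depends on the dimethylamino group itself, since only the whole 4-(dimethylamino)phenyl group is tested here. A primary amine, a pyrrolidine or a morpholine in its place would test how much of that group the value of compound 4 requires.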